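Swapping propoxy for amino on the aryl piperazine

The source may hold more compounds than are shown below. What is called first, only, known or untested is meant among the compounds shown, and "the series" means these compounds.

Measured so far:
compound 1 `COc1cccc2c1CCC(=O)N2CCCN1CCN(c2cccc(C(F)(F)F)c2)CC1` gives 490 nM in an assay on cell membranes for binding affinity to Sigma non-opioid intracellular receptor 1 (Rattus norvegicus); a lower number here means a stronger inhibitor, a higher number a weaker inhibitor
compound 2 `CCCOc1cccc(N2CCN(CCCN3C(=O)CCc4c(Cl)cccc43)CC2)c1` gives 370 nM in this assay

On the numbers shown, compound 2 and compound 1 lie within the usual scatter of each other, so neither can be called the stronger binder. Compound 3 `Nc1cccc(N2CCN(CCCN3C(=O)CCc4c(Cl)cccc43)CC2)c1` has not been measured. It differs from compound 2 in one place: amino in place of propoxy on an aromatic carbon. Within the data shown here, no measured pair shows this same change, so the size of the step can only be estimated. Compound 3 is expected to give a higher number in this assay, a step of a 2.4-fold higher number from compound 2 to compound 3 (0.39 log units; beyond the scatter) that goes beyond the scatter. Compound 3 is estimated at 900 nM, with a likely range from 300 nM to 3000 nM.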

Compound 3, half-maximal inhibitory concentration: 710 nM
Beside the measured number, compound 3's estimate is 1.3-fold (0.10 log units) above it; the range from low to high includes it.
By their numbers in this assay, from the lowest: compounds 2, 1 and 3 (each within the scatter of the next).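

In this assay, amino in place of propoxy on this aromatic carbon gives a small step (a 1.9-fold higher number from compound 2 to compound 3 (0.28 log units; within the scatter)). At this place on the ring, then, a group of 4 heavy atoms and a group of 1 heavy atom carrying a hydrogen-bond donor cannot be told apart by this measurement. No other data here bear on this result.

From the compounds shown here alone, whether a longer chain such as butoxy, or a carboxylic acid, at this place would move the number beyond the scatter remains open. So does whether this change behaves alike on other cores, as this is the only pair showing it.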